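The source may report more compounds than this note shows. Statements on the series, on what has been measured and on what is new or still open speak of the compounds shown alone.

Working notes on the series.

Of the compounds shown here, three on one shared core have been measured in a functional assay on MDA-MB-435 cells (Homo sapiens) (a lower number here means a stronger inhibitor of growth, a higher number a weaker inhibitor of growth), so far. Compound 1 `COc1cccc(-c2cc(O)c3c(C)cc(C)nc3n2)c1` gives < 10 nM and this value is a limit of the assay rather than a number. Compound 3 `COc1cccc(-c2cc(O)c3c(C)ccnc3n2)c1` likewise gives < 10 nM which is again a limit. Among the compounds with values here, compound 2 `COc1ccccc1-c1cc(O)c2cccnc2n1` gives 39800 nM and this is the only number among the three values. The step that the two limits leave unreadable from compound 3 to compound 1 is the change methyl in place of hydrogen on an aromatic carbon and its size cannot be read since both ends sit at the limit of < 10 nM in this assay, at which 2 of the 3 values shown sit. Compounds 2 and 3 differ in more than one place and the difference between the two cores is not broken down here.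

Compound 4 `COc1ccccc1-c1cc(O)c2c(C)ccnc2n1` is not yet measured. It differs from compound 2 by methyl in place of hydrogen on an aromatic carbon. Within the data shown here, this is the same kind of change as the one from compound 3 to compound 1 but not the same: in compound 4 the entering methyl sits ortho to a fused ring, meta to a fused ring and opposite the ring nitrogen, whereas in compound 1 it sits next to the ring nitrogen, meta to a fused ring, meta to a methyl group and para to a fused ring. The measured step gives no readable size for such a methyl, so the expectation rests mainly on compound 2 and its value 39800 nM in this assay. Compound 4 is expected to move by a 2.7-fold lower number from compound 2 to compound 4 (0.42 log units; beyond the scatter) in this assay and this step is taken as modest beside the unreadable one. The estimate for compound 4 in this assay is 15000 nM with an expected range from 3000 nM to 60000 nM.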

Compound 4, concentration for 50% growth inhibition: 6460 nM
Estimate against measurement, compound 4: 2.3-fold (0.37 log units) above; the range from low to high includes it.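

On the core of compound 2, methyl in place of hydrogen on an aromatic carbon, opposite the ring nitrogen, gives a 6.2-fold lower number from compound 2 to compound 4 (0.79 log units; beyond the scatter) in this assay, so on this core the change has a measurable size, beyond the scatter. The same kind of change on the other core, from compound 3 to compound 1, cannot be read because both of its ends are limits and not numbers: the limit of < 10 nM in this assay, at which 2 of the 4 values shown sit. The size seen on the core of compound 2 therefore has no second readable step to be checked against, and the methyl of compound 1 enters at a different place on the ring, so even a readable step there would not be the identical change; whether the effect carries from one core to the other is neither shown nor ruled out.

The compounds shown leave open what a methyl at the place it holds in compound 1 would do on the core of compound 2. They also leave open whether an ethyl group, a longer chain or an amine, opposite the ring nitrogen, would take the number further down than methyl does or bring it back up.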